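This account rests on a few compounds, and the source may have more. Where it says the series, first, only, none or still open, it means among the compounds named here.

Working notes on the bromo-substituted series. In a functional assay on the whole organism with Rattus norvegicus as the target, at a dose of 20 mg/kg by the oral route (a higher number here means more inhibition at the dose given (going by the name of the read-out), a lower number less inhibition), compound 1 `CNC(=O)/C=C1\CCc2ccc(Br)cc21` gives 44%, and compound 2 `NC(=O)/C=C1\CCc2ccc(Br)cc21` gives 38%. Among the two numbers shown, compound 2 stands within the scatter of compound 1: the single measured step at the amide-type nitrogen, a number 6 percentage points lower from compound 1 to compound 2 (within the scatter), is too small to count as a real change. Compound 3 `O=C(/C=C1\CCc2ccc(Br)cc21)NC1CC1` differs from compound 2 by cyclopropyl in place of hydrogen on an amide-type nitrogen. Among the measured compounds shown here, the only step that touches this place is the one from methyl to hydrogen, and it was within the scatter; no measured step brings in a cyclopropyl, so nothing in the data points to a movement in either direction beyond the scatter. The step from compound 2 to compound 3 is therefore expected to be about a number 4 percentage points higher from compound 2 to compound 3 (within the scatter), with no change that could be told from repeat variation. For compound 3 in this assay the estimate is 42%, with a range of 25% to 60%.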

Compound 3, a percentage reported as inhibition, in the whole organism at one dose (the size of the read-out at that dose, not a potency): 29%
Beside the measured number, compound 3's estimate is 13 percentage points above it, and the stated range covers the measured number.
By their numbers in this assay, from the lowest: compounds 3, 2 and 1 (each within the scatter of the next, the first and the last beyond it).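

Among the compounds shown here, at the amide-type nitrogen, the swap of methyl for cyclopropyl gives the first step at this position that lies beyond the scatter in this assay (a number 15 percentage points lower from compound 1 to compound 3 (beyond the scatter)), though it is modest, while cyclopropyl in place of hydrogen stays within the scatter (a number 9 percentage points lower from compound 2 to compound 3 (within the scatter)). The groups on this nitrogen therefore do not all read alike: methyl and cyclopropyl can be told apart, while hydrogen cannot be told from either. Nothing at hand explains this difference.

Going by these compounds, it remains open whether a larger ring such as cyclobutyl, a longer chain such as n-propyl, or a chain carrying an amine or a carboxylic acid would read with methyl or with cyclopropyl. On these data alone, all three compounds carry bromine, so whether the gap between methyl and cyclopropyl survives with chlorine in its place is also open.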